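The source may report more compounds than this note shows. Statements on the series, on what has been measured and on what is new or still open speak of the compounds shown alone.

Measured compounds in an assay on lysate for inhibition of 6-phosphofructo-2-kinase/fructose-2,6-bisphosphatase 3 (Homo sapiens), with stated times of 0.5 min and 45 min; on this read-out higher numbers stand for weaker inhibition and lower numbers for stronger inhibition:
Compound 1 `CNC(=O)c1ccncc1Nc1cc(-c2ccc3ccn(C)c3c2)c2nccnc2c1`: 7020 nM
Compound 2 `CN1CCC(NC(=O)c2ccncc2Nc2cc(-c3ccc4ccn(C)c4c3)c3nccnc3c2)CC1=O`: 48800 nM

Compound 2 stands at the higher of the two numbers in this assay, above compound 1 by a 7.0-fold higher number from compound 1 to compound 2 (0.84 log units; beyond the scatter). Compound 3 `CN1CC(NC(=O)c2ccncc2Nc2cc(-c3ccc4ccn(C)c4c3)c3nccnc3c2)CCC1=O` differs from compound 2 by 1-methyl-6-oxopiperidin-3-yl in place of 1-methyl-2-oxopiperidin-4-yl on an amide-type nitrogen. Within the data shown here, no measured step bears directly on this change; the only step available, a 7.0-fold higher number from compound 1 to compound 2 (0.84 log units; beyond the scatter), concerns the arrival of the ring itself rather than the point at which it is joined. Compound 3 is therefore expected to give a number close to that of compound 2, a step of a 1.2-fold lower number from compound 2 to compound 3 (0.09 log units; within the scatter). The estimate for compound 3 is 40000 nM, with a range from 15000 nM to 120000 nM.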

Compound 3, half-maximal inhibitory concentration: 96500 nM
Beside the measured number, compound 3's estimate is 2.4-fold (0.38 log units) below it; measured number inside the range.
By their numbers in this assay, from the lowest: compound 1; then compounds 2 and 3 (each within the scatter of the next).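

In this assay, 1-methyl-6-oxopiperidin-3-yl in place of 1-methyl-2-oxopiperidin-4-yl on the amide-type nitrogen gives a step within the scatter (a 2.0-fold higher number from compound 2 to compound 3 (0.30 log units; within the scatter)), so these two ways of joining the ring cannot be told apart here. Against methyl on that nitrogen, the second ring also gives a higher number (a 14-fold higher number from compound 1 to compound 3 (1.14 log units; beyond the scatter)), so compound 1 stays below both ring compounds. Nothing measured here explains why either ring raises the number. The compounds shown leave open whether an open chain such as 2-methoxyethyl, or a piperidin-4-yl ring without the carbonyl, would stay near compound 1 or near the ring compounds.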